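Replacing Phenyl with 2-Fluorobenzyl on the Amide Nitrogen

The source may report more compounds than this note shows. Statements on the series, on what has been measured and on what is new or still open speak of the compounds shown alone.

In a functional assay on Huh-7 cells (Homo sapiens) for inhibition, read by MTT assay, with a stated time of 48 h (on this read-out higher numbers stand for weaker inhibition and lower numbers for stronger inhibition), compound 2 (`COc1ccc2c(=O)c(/C=C/C(=O)Nc3ccccc3)coc2c1`) gives 9050 nM as its half-maximal inhibitory concentration. In this assay compound 3 (`COc1ccc2c(=O)c(/C=C/C(=O)NCc3cccc(F)c3)coc2c1`) gives 10100 nM and compound 1 (`O=C(/C=C/c1coc2cc(O)ccc2c1=O)NCc1ccccc1`) gives 4690 nM on the same read-out, so both lie within the scatter of compound 2.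

Compound 4 (`COc1ccc2c(=O)c(/C=C/C(=O)NCc3ccccc3F)coc2c1`) has 2-fluorobenzyl in place of phenyl on an amide-type nitrogen. Among the measured compounds shown here, no measured compound carries 2-fluorobenzyl itself. The nearest evidence is compound 3, which has 3-fluorobenzyl in place of phenyl on an amide-type nitrogen. That measured step is a 1.1-fold higher number from compound 2 to compound 3 (0.05 log units; within the scatter) and stays within the scatter.

On this single step, no change beyond the scatter is expected in this assay for the new replacement. The expected step is a 1.0-fold higher number from compound 2 to compound 4 (0.02 log units; within the scatter) and would be too small to read as a direction. For compound 4 the estimated value is 9500 nM with an expected range from 4800 nM to 19000 nM in repeated measurements.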

Compound 4, half-maximal inhibitory concentration: 8450 nM
Estimate against measurement, compound 4: 1.1-fold (0.05 log units) above, within the range that was stated.
By their numbers in this assay, from the lowest: compounds 1, 4, 2 and 3 (each within the scatter of the next, the first and the last beyond it).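

In this assay, 2-fluorobenzyl in place of phenyl on the amide-type nitrogen gives a 1.1-fold lower number from compound 2 to compound 4 (0.03 log units; within the scatter), so a second fluorine-bearing benzyl group now stays within the scatter of phenyl. Exchanging 3-fluorophenyl for 2-fluorophenyl on the saturated chain carbon bound to the amide-type nitrogen gives a 1.2-fold lower number from compound 3 to compound 4 (0.08 log units; within the scatter), so the two fluorine placements cannot be told apart in this assay. Nothing presented here explains why these changes leave the number within the scatter.

As far as these compounds go, it remains open whether an amine, a carboxylic acid or a longer chain such as phenethyl in place of phenyl on the amide-type nitrogen would move the number beyond the scatter. Compound 1 differs from the other compounds in more than one place, so it cannot show what benzyl without fluorine does on the core of compound 2.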